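Pyridin-2-yl in place of 3-chlorophenyl: outlook for compound 4

The source may report more compounds than this note shows. Statements on the series, on what has been measured and on what is new or still open speak of the compounds shown alone.

In an assay on LM cells for displacement of a labelled ligand from Neuropeptide Y receptor type 5 (Homo sapiens) (on this read-out lower numbers stand for stronger inhibition and higher numbers for weaker inhibition), compound 1 `Fc1ccc(C2(c3ccc(F)cc3)CNC(c3cccc(Cl)c3)=N2)cc1` gives 5.4 nM. Compound 2 `N#Cc1cccc(C2=NC(c3ccc(F)cc3)(c3ccc(F)cc3)CN2)c1` gives 2.7 nM in this assay, and compound 3 `Fc1ccc(C2(c3ccc(F)cc3)CNC(c3cccs3)=N2)cc1` gives 54 nM. Compound 1 thus stands second highest of the three numbers. The change to compound 2 is a 2.0-fold lower number from compound 1 to compound 2 (0.30 log units; within the scatter), within the scatter, whereas the change to compound 3 is a 10-fold higher number from compound 1 to compound 3 (1.00 log units; beyond the scatter), and from compound 2 the step to compound 3 is a 20-fold higher number from compound 2 to compound 3 (1.30 log units; beyond the scatter).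

Compound 4 `Fc1ccc(C2(c3ccc(F)cc3)CNC(c3ccccn3)=N2)cc1` differs from compound 1 as follows: pyridin-2-yl in place of 3-chlorophenyl on a carbon with a double bond to nitrogen. Among the measured compounds shown here, the one measured step that bears on this change is a 10-fold higher number from compound 1 to compound 3 (1.00 log units; beyond the scatter), where another heteroaryl group, thiophen-2-yl, took the place of 3-chlorophenyl on the same carbon and the number rose clearly. Pyridin-2-yl keeps a six-membered aromatic ring but removes the chlorine, so a weakening of moderate size is expected, beyond the scatter yet smaller than with thiophen-2-yl. For compound 4 the expected step is a 3.7-fold higher number from compound 1 to compound 4 (0.57 log units; beyond the scatter). Compound 4 is therefore estimated at 20 nM in this assay, with a range from 7 nM to 60 nM.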

Compound 4, half-maximal inhibitory concentration: 160 nM
Compound 4: middle estimate off by 8.0-fold (0.90 log units), on the low side; the whole stated range lies below it.
By their numbers in this assay, from the lowest: compounds 2 and 1 (each within the scatter of the next); then compound 3; then compound 4.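

In this assay, a six-membered aromatic ring on this carbon does not by itself keep the number low: pyridin-2-yl gives a 30-fold higher number from compound 1 to compound 4 (1.47 log units; beyond the scatter), and it also falls behind the five-membered thiophen-2-yl, with a 3.0-fold higher number from compound 3 to compound 4 (0.47 log units; beyond the scatter). Among the compounds shown here, the widest step is a 59-fold higher number from compound 2 to compound 4 (1.77 log units; beyond the scatter), and across these four compounds the two groups carrying chloro or cyano on a phenyl ring, in compounds 1 and 2, stand clearly below the two unsubstituted heteroaryl groups, in compounds 3 and 4, with no compound going against this. No measured evidence on the cause of these steps is at hand.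

Compound 4 differs from compound 1 both by the ring nitrogen and by the loss of the chlorine, so the compounds shown do not separate these two changes, and an unsubstituted phenyl group on this carbon would be the direct comparison. Also open, as far as these compounds go, is whether a pyridine ring carrying chlorine or a nitrile returns the number towards that of compound 1, and whether the ring nitrogen placed elsewhere, as in pyridin-3-yl, behaves as pyridin-2-yl does.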